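The compounds below may be only part of what the source reports. "The series", "measured", "known", "first", "only" and "open" are said of these compounds alone.

Compound 1, `O=C(Nc1cccc(-c2oc3cc(-c4ccc(F)cc4)ccc3c(=O)c2O)c1)c1ccc(F)cc1`, gives 6930 nM in a functional assay on A549 cells (Homo sapiens) for antiproliferative activity, read by CCK-8 assay, with a stated time of 72 h; a higher number here means a weaker inhibitor, a lower number a stronger inhibitor. Compound 2, `Cc1ccc(C(=O)Nc2cccc(-c3oc4cc(-c5ccc(F)cc5)ccc4c(=O)c3O)c2)cc1`, gives 6910 nM. Compound 3, `COc1cccc(C(=O)Nc2cccc(-c3oc4cc(-c5ccc(F)cc5)ccc4c(=O)c3O)c2)c1`, gives 10800 nM.

Within this small set, compound 3 has the number that sits at the top, yet its distances to compound 1 and to compound 2 are both within the usual scatter of repeated measurements, so none of the three can be set apart from the others on the evidence at hand. All three share the same core and differ only in the ring attached to the carbonyl carbon of the amide.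

Compound 4, `O=C(Nc1cccc(-c2oc3cc(-c4ccc(F)cc4)ccc3c(=O)c2O)c1)c1cc(F)cc(F)c1`, continues this series of amide variations. The change from compound 3 is 3,5-difluorophenyl in place of 3-methoxyphenyl on a carbonyl carbon.

Three steps speak to this change. The step of a 1.6-fold higher number from compound 1 to compound 3 (0.19 log units; within the scatter) and the step of a 1.6-fold higher number from compound 2 to compound 3 (0.19 log units; within the scatter) both alter the same ring on the carbonyl carbon and stay within the scatter. The step of a 1.0-fold lower number from compound 1 to compound 2 (0.00 log units; within the scatter) also exchanges a substituent on that ring without a change beyond the scatter. Nothing among these measurements suggests that the ring on the carbonyl carbon shifts the number much, so the step from compound 3 to compound 4 is expected to be a 1.4-fold lower number from compound 3 to compound 4 (0.13 log units; within the scatter), no more than the scatter in either direction. Compound 4 is therefore estimated to give 8000 nM, with a likely range from 4000 nM to 16000 nM.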

Compound 4, half-maximal inhibitory concentration: 7620 nM
Compound 4: the middle estimate sits 1.0-fold (0.02 log units) above what was measured, and the stated range covers the measured number.
By their numbers in this assay, from the lowest: compounds 2, 1, 4 and 3 (each within the scatter of the next).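

Placing 3,5-difluorophenyl on the carbonyl carbon in place of 3-methoxyphenyl removes the ring's oxygen and its one hydrogen-bond acceptor and brings in two fluorines, yet the result in this assay stays within the scatter (a 1.4-fold lower number from compound 3 to compound 4 (0.15 log units; within the scatter)). The comparisons with the other two amides read the same way (a 1.1-fold higher number from compound 2 to compound 4 (0.04 log units; within the scatter); a 1.1-fold higher number from compound 1 to compound 4 (0.04 log units; within the scatter)), so a ring carrying two substituents, with no oxygen in them, cannot be set apart from the rings carrying one, and across compounds 1 to 4 this position shows no measurable preference among these substituted phenyl rings. No measurement in hand offers an explanation for this flat result.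

All four compounds keep a six-membered aromatic ring of carbon only on the carbonyl carbon, so they do not tell whether a saturated ring, a longer alkyl chain, or a phenyl ring bearing an amine or a carboxylic acid would move the number beyond the scatter. The rest of the molecule is also the same throughout, which leaves open how much the shared core itself contributes to the antiproliferative effect.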